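The source may report more compounds than this note shows. Statements on the series, on what has been measured and on what is new or still open speak of the compounds shown alone.

Compound 1 `N#Cc1c(N)sc(C(=O)Nc2ccc(Cl)cc2)c1-c1ccccc1`: 420 nM
Compound 2 `N#CCC(=O)Nc1sc(C(=O)Nc2ccc(Cl)cc2)c(-c2ccccc2)c1C#N`: 590 nM

Both values come from a functional assay on MKN-45 cells (Homo sapiens) for inhibition, read by MTT assay; on this read-out lower numbers stand for stronger inhibition and higher numbers for weaker inhibition. For the measured compounds named here, compound 1 stands level with compound 2, its only measured neighbour, and the two cannot be ranked: a 1.4-fold higher number from compound 1 to compound 2 (0.15 log units; within the scatter). Compound 3 `N#Cc1c(N)sc(C(=O)Nc2ccccc2)c1-c1ccccc1` differs from compound 1 elsewhere in the structure: hydrogen in place of chloro on an aromatic carbon. Put simply, hydrogen sits in place of chloro on an aromatic carbon, turning 4-chlorophenyl into phenyl. The measured step adds a (cyanomethyl)carbonyl at a different place, so it bears on this change only loosely. Going by the values given here, it shows one edit of compound 1 that stayed within the scatter, but no measured pair tests the chloro itself. Going by these compounds, a change beyond the scatter is therefore not expected, though the direction remains open and the range must stay wide. The expected move is a 1.4-fold higher number from compound 1 to compound 3 (0.15 log units; within the scatter). Compound 3 is estimated at 600 nM, within an expected range of 220 nM to 1700 nM.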

Compound 3, half-maximal inhibitory concentration: 7090 nM
Compound 3: the middle estimate sits 12-fold (1.07 log units) below what was measured; the measured number lies above the stated range.
By their numbers in this assay, from the lowest: compounds 1 and 2 (each within the scatter of the next); then compound 3.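

Swapping the chloro for hydrogen gives a 17-fold higher number from compound 1 to compound 3 (1.23 log units; beyond the scatter) in this assay, so a change of a single atom on this aromatic carbon, para to a large group, moves the result well beyond the scatter. The earlier step, at a different place on compound 1, stayed within the scatter, so it gave no sign that this position would be so sensitive. Nothing shown here explains why this chloro matters so much.

Going by these compounds, it remains open whether chloro is special at this position or whether a fluoro, bromo, methyl or methoxy group would serve as well. On these data alone, it is also open whether removing the chloro would cost as much in compound 2, where the amino group carries the (cyanomethyl)carbonyl.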